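A few compounds are considered here, and "the series" means these few. Any claim that something is new, unique, unknown or untested is made for them only; others in the source may bear on it.

Measured compounds in an assay on tissue (HeLa cells) for inhibition of Indoleamine 2,3-dioxygenase 1 (Homo sapiens), read by spectrophotometry; a lower number here means a stronger inhibitor, a higher number a weaker inhibitor:
- compound 1 `OCc1cc2cc(/C(=N\O)Nc3cccc(F)c3)ccc2o1`: 2400 nM
- compound 2 `OCc1cc2cc(/C(=N\O)Nc3cccc(Cl)c3)ccc2o1`: 5900 nM
- compound 3 `OCc1cc2cc(/C(=N\O)Nc3cccc(Br)c3)ccc2o1`: 1200 nM

Compound 1 stands second highest of the three numbers. Its nearest neighbour is compound 3, reached by a 2.0-fold lower number from compound 1 to compound 3 (0.30 log units; within the scatter), a step within the scatter; its furthest is compound 2, reached by a 2.5-fold higher number from compound 1 to compound 2 (0.39 log units; beyond the scatter), a step beyond the scatter. Between the two halogen analogues the step of a 4.9-fold lower number from compound 2 to compound 3 (0.69 log units; beyond the scatter) is also beyond the scatter, though modest.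

Compound 4 `O/N=C(/Nc1cccc(F)c1)c1ccc2oc(-c3ccccc3)cc2c1` is not yet measured. It differs from compound 1 in one place: phenyl in place of hydroxymethyl on an aromatic carbon. Going by the values given here, none of the measured steps bears on this change. All three concern the halogen on the aniline ring and leave the hydroxymethyl on the five-membered ring untouched, so the series gives no guide to what happens when that group is exchanged for phenyl. The expectation for compound 4 therefore rests on compound 1 alone, and the estimate must carry a wide range.

Compound 4 is expected to give roughly 2000 nM in this assay, within 300 nM to 12000 nM, which means an expected step of a 1.2-fold lower number from compound 1 to compound 4 (0.08 log units; within the scatter) from compound 1, not resolvable beyond the scatter.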

Compound 4, half-maximal inhibitory concentration: 10600 nM
The estimate for compound 4 lay 5.3-fold (0.72 log units) below the measured number, within the range that was stated.
By their numbers in this assay, from the lowest: compounds 3 and 1 (each within the scatter of the next); then compounds 2 and 4 (each within the scatter of the next).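

In this assay, exchanging hydroxymethyl for phenyl on the aromatic carbon next to the ring oxygen gives a 4.4-fold higher number from compound 1 to compound 4 (0.65 log units; beyond the scatter), a first sign that the number responds to a change at this position, which all the halogen steps left untouched. The step is modest but beyond the scatter, and compound 4 still gives a measurable number with phenyl in this place. The change alters several counted features at once, removing a hydrogen-bond donor and acceptor and bringing in a six-membered aromatic ring of carbon only, and no measurement accompanying the result ties the step to any one of them.

The compounds shown leave open whether the higher number follows the loss of the hydroxyl or the arrival of the phenyl; a methyl, a methoxymethyl, an aminomethyl or a carboxylic acid at the same carbon would help separate the two. They also leave open whether the order among the fluoro, chloro and bromo compounds holds when phenyl occupies this position.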